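Removing the Trifluoromethyl Group from a Weak Growth Inhibitor

The source may report more compounds than this note shows. Statements on the series, on what has been measured and on what is new or still open speak of the compounds shown alone.

Compound 1 `O=C(CCN1C(=O)CSc2ccccc21)N1CCN(c2ccc([N+](=O)[O-])cc2)CC1`: 68100 nM
Compound 2 `COc1ccccc1N1CCN(CCCNC(=O)CCN2C(=O)CSc3ccccc32)CC1`: 59200 nM
Compound 3 `O=C(CCN1C(=O)CSc2ccccc21)NCCCN1CCN(c2ccc(C(F)(F)F)cc2)CC1`: > 100000 nM

In a functional assay (MiaPaCa cells, Homo sapiens) for inhibition, read by sulforhodamine B assay, with a stated time of 48 h (a higher number here means a weaker inhibitor of growth, a lower number a stronger inhibitor of growth), compound 1 gives 68100 nM and compound 2 gives 59200 nM. For compound 3 the assay reports only a limit, > 100000 nM, so compound 3 stands at the weak end of the three, without a number of its own. The step of an at least 1.6-fold higher number from compound 2 to compound 3 (0.22 log units; that floor lies within the scatter) is thus only a floor and lies within the scatter. Compound 4 `O=C(CCN1C(=O)CSc2ccccc21)NCCCN1CCN(c2ccccc2)CC1` differs from compound 3 by hydrogen in place of trifluoromethyl on an aromatic carbon. Going by the values given here, the one measured step that bears on this, an at least 1.6-fold higher number from compound 2 to compound 3 (0.22 log units; that floor lies within the scatter), swapped the aryl group on the same amine nitrogen in a ring and stayed within the scatter. No step beyond the scatter is therefore expected. Compound 4 is estimated at 85000 nM, with a range from 40000 nM to 200000 nM. The expected step is an at least 1.1-fold lower number from compound 3 to compound 4 (0.07 log units; that floor lies within the scatter).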

Compound 4, concentration for 50% growth inhibition: > 100000 nM
Compound 4 gave a limit, no number (the forecaster's own chance of this, stated with the estimate: 40%); middle value at least 1.1-fold (0.07 log units) away from the limit.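

Compound 3 and compound 4 both stand as limits in this assay, so the change from trifluoromethyl to hydrogen cannot be read, because neither compound has a number of its own: the limit of > 100000 nM in this assay, at which 2 of the 4 values shown sit. What can be read is the step of an at least 1.6-fold higher number from compound 2 to compound 4 (0.22 log units; that floor lies within the scatter), which is only a floor and does not set hydrogen apart from methoxy on the aromatic carbon. Left open is whether an amine or a carboxylic acid on that aromatic carbon, para to a large group, would give a number of its own in this assay.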